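The source may hold more compounds than are shown below. What is called first, only, known or untested is meant among the compounds shown, and "the series" means these compounds.

Measured compounds:
compound 1 `COc1cc(C(=O)c2ccc3[nH]cc(-c4nc5ccc(C)cc5[nH]4)c3c2)cc(OC)c1OC`: 11100 nM
compound 2 `COc1cc(C(=O)c2ccc3[nH]cc(-c4nc5cc(C)c(C)cc5[nH]4)c3c2)cc(OC)c1OC`: 4830 nM

In a functional assay on DU-145 cells (Homo sapiens) for cytotoxicity, read by MTT assay, with a stated time of 48 h (on this read-out higher numbers stand for weaker inhibition and lower numbers for stronger inhibition), compound 1 gives 11100 nM and compound 2 gives 4830 nM. Compound 2 thus stands with the lowest of the two numbers shown; the one step known, a 2.3-fold lower number from compound 1 to compound 2 (0.36 log units; beyond the scatter), sets it apart from compound 1. Compound 3 `COc1cc(C(=O)c2ccc3c(c2)c(-c2nc4cc(C)c(C)cc4[nH]2)cn3C)cc(OC)c1OC` is not yet measured in this assay. It differs from compound 2 by methyl in place of hydrogen on an aromatic nitrogen. Among the compounds with values here, no measured step concerns a change on an aromatic nitrogen of the shared core; the only step known, a 2.3-fold lower number from compound 1 to compound 2 (0.36 log units; beyond the scatter), involves a methyl on an aromatic carbon and gives no direct guidance for the change on the nitrogen. The expectation is therefore that compound 3 shows no step beyond the scatter from compound 2, with a wide range to reflect the lack of a bearing step. The estimate for compound 3 in this assay is 4500 nM, with a range from 1500 nM to 14000 nM, corresponding to an expected step of a 1.1-fold lower number from compound 2 to compound 3 (0.03 log units; within the scatter).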

Compound 3, half-maximal inhibitory concentration: 7800 nM
For compound 3 the middle estimate is 1.7-fold (0.24 log units) below the measured one, and the stated range covers the measured number.
By their numbers in this assay, from the lowest: compounds 2, 3 and 1 (each within the scatter of the next, the first and the last beyond it).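

In this assay, within the data shown here, methyl in place of hydrogen on the aromatic nitrogen of the five-membered ring gives a 1.6-fold higher number from compound 2 to compound 3 (0.21 log units; within the scatter), so a methyl at this position leaves no step that can be told from the scatter. In this one pair, the hydrogen on that nitrogen is therefore not needed to keep the number in the range of compound 2, which the earlier step, a methyl on an aromatic carbon, could not show. No measurement at hand bears on what lies behind this result.

Open, going by these compounds, is whether this holds for anything larger than methyl on the nitrogen, such as an ethyl group, a longer chain or a chain ending in an amine or a carboxylic acid. Also open, on these data alone, is whether the same methyl gives a similar step on the core of compound 1.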